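The compounds below may be only part of what the source reports. "The series", "measured", "known", "first", "only" and "open" are said of these compounds alone.

Three analogues of the shared core differ only in the aryl group on an amide-type nitrogen. Compound 1 `COc1cc(NC(C)CCCNC(=O)NNC(=O)Nc2cccc(F)c2)c2ncccc2c1` gives 108000 nM in a functional assay on L1210 cells (Mus musculus) for inhibition, read by MTT assay, with a stated time of 72 h; on this read-out lower numbers stand for stronger inhibition and higher numbers for weaker inhibition; compound 2 `COc1cc(NC(C)CCCNC(=O)NNC(=O)Nc2ccc(Br)cc2)c2ncccc2c1` gives 51000 nM; compound 3 `COc1cc(NC(C)CCCNC(=O)NNC(=O)Nc2cccc(Cl)c2)c2ncccc2c1` gives 27000 nM, the lowest of the three numbers, although only a 1.9-fold lower number from compound 2 to compound 3 (0.28 log units; within the scatter) separates it from compound 2, whereas a 4.0-fold lower number from compound 1 to compound 3 (0.60 log units; beyond the scatter) and a 2.1-fold lower number from compound 1 to compound 2 (0.33 log units; beyond the scatter) lie beyond the scatter. Compound 4 `COc1cc(NC(C)CCCNC(=O)NNC(=O)Nc2ccc(C(F)(F)F)cc2)c2ncccc2c1` differs from compound 3 by 4-(trifluoromethyl)phenyl in place of 3-chlorophenyl on an amide-type nitrogen. The step that bears most on this, swapping 4-bromophenyl for 3-chlorophenyl, was a 1.9-fold lower number from compound 2 to compound 3 (0.28 log units; within the scatter) and within the scatter, so a further change of aryl group is expected to move the number little. The step is expected to be a 1.5-fold higher number from compound 3 to compound 4 (0.17 log units; within the scatter). Compound 4 is accordingly estimated at 40000 nM, within 15000 nM to 110000 nM.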

Compound 4, half-maximal inhibitory concentration: 18000 nM
Beside the measured number, compound 4's estimate is 2.2-fold (0.35 log units) above it; measured number inside the range.
By their numbers in this assay, from the lowest: compounds 4, 3 and 2 (each within the scatter of the next, the first and the last beyond it); then compound 1.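

In this assay the amide-type nitrogen also carries a non-halogen aryl substituent, with 4-(trifluoromethyl)phenyl in place of 3-chlorophenyl giving a 1.5-fold lower number from compound 3 to compound 4 (0.18 log units; within the scatter) and leaving the two compounds unseparated. Trifluoromethyl in place of bromo gives a 2.8-fold lower number from compound 2 to compound 4 (0.45 log units; beyond the scatter) and so separates a pair of para-free-named neighbours only modestly, while the swap from 3-fluorophenyl gives a 6.0-fold lower number from compound 1 to compound 4 (0.78 log units; beyond the scatter) as the widest step in the series. No evidence on hand accounts for these steps.

Still open, as far as these compounds go, is whether a nitrile, an amine or a carboxylic acid on the aryl ring would hold this level. From the compounds shown here alone, the effect of a longer chain on the shared core also stays open.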